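The source may hold more compounds than are shown below. What is called first, only, known or untested is meant among the compounds shown, and "the series" means these compounds.

Measured compounds in this series:

Compound 1 `CC(C)C(Nc1nccs1)c1ccc(-c2ccc3cccc(F)c3c2)[nH]c1=O` gives 10 nM in a functional assay on CHO cells for antagonist activity at prostaglandin E2 receptor EP3 subtype (Homo sapiens), read by cAMP accumulation; on this read-out lower numbers stand for stronger inhibition and higher numbers for weaker inhibition.
Compound 2 `CCn1ncc2c(F)cc(-c3ccc(C(CC)(CC)c4nnc(C)[nH]4)c(=O)[nH]3)cc21` gives 90 nM in this assay.
Compound 3 `CCn1ncc2c(F)cc(-c3ccc(C(CC)(CC)c4nnc[nH]4)c(=O)[nH]3)cc21` gives 29 nM in this assay.

Compound 1 stands at the lowest number of the three; compound 3 is nearest, with a number beyond the scatter above it, and compound 2 is furthest. For the measured compounds named here, the only step between compounds that differ in one place is a 3.1-fold lower number from compound 2 to compound 3 (0.49 log units; beyond the scatter), a change on the triazole of a different core from that of compound 1.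

Compound 4 `CC(C)C(c1cnc(N)s1)c1ccc(-c2ccc3cccc(F)c3c2)[nH]c1=O` is not yet measured. It differs from compound 1 in the group on the saturated chain carbon: 2-amino-1,3-thiazol-5-yl in place of (1,3-thiazol-2-yl)amino on a saturated chain carbon bound to an aromatic carbon and a saturated chain carbon. The two compounds hold the same atoms, joined differently. Going by the values given here, no measured step touches this kind of rearrangement; the step from compound 2 to compound 3 concerns another ring on another core and gives no direct guide. With compound 1 at 10 nM as the only anchor, the expectation is that compound 4 keeps a number near that of compound 1, with a modest shift in either direction possible, the estimated step being a 2.5-fold higher number from compound 1 to compound 4 (0.40 log units; beyond the scatter). Compound 4 is therefore estimated at 25 nM in this assay, with a range from 6 nM to 100 nM.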

Compound 4, half-maximal inhibitory concentration: 39 nM
Beside the measured number, compound 4's estimate is 1.6-fold (0.19 log units) below it; the measured number falls inside the stated range.
By their numbers in this assay, from the lowest: compound 1; then compounds 3 and 4 (each within the scatter of the next); then compound 2.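

In this assay, the group on the saturated chain carbon of the shared core responds to how its atoms are joined: the rearrangement gives a 3.9-fold higher number from compound 1 to compound 4 (0.59 log units; beyond the scatter), although (1,3-thiazol-2-yl)amino and 2-amino-1,3-thiazol-5-yl hold the same heavy atoms and the same counts of hydrogen-bond donors and acceptors. For the compounds shown here, the step is thus the only reading at this position, since the earlier step concerned the triazole of another core, and it shows that identical counts do not guarantee an unchanged number here, while inhibition is still measurable after the change. The compounds shown offer no measurement that accounts for the size of this step.

On these data alone, the rearrangement changes the point of attachment of the ring and the place of the amine together, so the share of each in the step remains open. Also open, as far as these compounds go, is where a plain 1,3-thiazol-5-yl group, or a methylamino group in place of the amine of 2-amino-1,3-thiazol-5-yl, would fall relative to compound 1 and compound 4 on this core.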